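A few compounds are considered here, and "the series" means these few. Any claim that something is new, unique, unknown or untested is made for them only; others in the source may bear on it.

Measured so far: compound 1 `COc1cc(-c2nn(-c3cccc(NC(=O)Nc4ccc(Cl)c(Cl)c4)c3)cc2-c2ccncc2)ccc1Cl` gives 931 nM in a functional assay on OVCAR-8 cells (Homo sapiens) for inhibition, read by sulforhodamine B assay, with a stated time of 48 h; a lower number here means a stronger inhibitor of growth, a higher number a weaker inhibitor of growth; compound 2 `COc1cc(-c2nn(-c3cccc(NC(=O)Nc4ccc(Cl)c(C(F)(F)F)c4)c3)cc2-c2ccncc2)ccc1Cl` gives 1050 nM.

Compound 2 holds the higher of these two numbers, though the step of a 1.1-fold higher number from compound 1 to compound 2 (0.05 log units; within the scatter) lies within the scatter. Compound 3 `COc1cc(-c2nn(-c3cccc(NC(=O)c4ccccc4)c3)cc2-c2ccncc2)ccc1Cl` is the next step from compound 2: phenyl in place of (4-chloro-3-(trifluoromethyl)phenyl)amino on a carbonyl carbon. Within the data shown here, the only measured step, from compound 1 to compound 2, concerns a different part of the molecule, so no measured step bears on this change. For compound 3 a weaker growth inhibition is expected, with a wide range, the step being a 5.7-fold higher number from compound 2 to compound 3 (0.76 log units; beyond the scatter). Compound 3 is estimated at 6000 nM, between 1200 nM and 30000 nM.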

Compound 3, concentration for 50% growth inhibition: 995 nM
For compound 3 the middle estimate is 6.0-fold (0.78 log units) above the measured one, outside the stated range (below it).
By their numbers in this assay, from the lowest: compounds 1, 3 and 2 (each within the scatter of the next).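

In this assay, putting phenyl in place of (4-chloro-3-(trifluoromethyl)phenyl)amino on the carbonyl carbon gives a 1.1-fold lower number from compound 2 to compound 3 (0.02 log units; within the scatter), and putting it in place of (3,4-dichlorophenyl)amino gives a 1.1-fold higher number from compound 1 to compound 3 (0.03 log units; within the scatter). At this position, then, the much larger halogen-bearing group with its nitrogen and hydrogen can go without the number leaving the scatter. No measurement available here explains this. Still open, from the compounds shown here alone, is whether a much smaller group on this carbonyl carbon, such as methyl, or a phenyl carrying a carboxylic acid or an amine, would give a similar number.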